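A phenyl replaces a methyl in compound 3

The source may hold more compounds than are shown below. What is called first, only, known or untested is meant among the compounds shown, and "the series" means these compounds.

Compound 1 `Cc1noc(C)c1[C@@H]1C[C@@](C)(c2ccc(F)cc2F)N=C(N)S1`: 78%
Compound 2 `Cc1onc(-c2ccc(F)cc2)c1[C@@H]1C[C@@](C)(c2ccc(F)cc2F)N=C(N)S1`: 35%

Among the measured compounds shown here, in an ADME assay on microsomes from liver (Rattus norvegicus) for metabolic stability, with a stated time of 10 min, tested at 0.5 uM (on this read-out higher numbers stand for a more stable compound and lower numbers for a less stable compound), compound 1 holds the higher of the two numbers so far, at 78%. Compound 3 `Cc1noc(-c2ccccc2)c1[C@@H]1C[C@@](C)(c2ccc(F)cc2F)N=C(N)S1` is the next to be read. It differs from compound 1 as follows: phenyl in place of methyl on an aromatic carbon. The new phenyl sits next to the ring oxygen.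

For the measured compounds named here, one measured step bears on this change: a number 43 percentage points lower from compound 1 to compound 2 (beyond the scatter), with 4-fluorophenyl in place of methyl on an aromatic carbon. It is a large step, beyond the scatter, but it is an imperfect guide. The group entering compound 2 carries a fluorine that phenyl lacks, and it sits on a different carbon of that ring. With a single step to go on, a large fall in this assay is expected, of about the same size and with wide uncertainty. The expected step is a number 40 percentage points lower from compound 1 to compound 3 (beyond the scatter). For compound 3 the estimated value is 38%, with an expected range of 16% to 62%.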

Compound 3, percent of the compound remaining: 20%
Compound 3: middle estimate off by 18 percentage points, on the high side, within the range that was stated.
By their numbers in this assay, from the lowest: compound 3; then compound 2; then compound 1.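

In this assay, putting phenyl in place of methyl on the aromatic carbon next to the ring oxygen gives a number 58 percentage points lower from compound 1 to compound 3 (beyond the scatter). Together with the earlier step, this shows that a large fall is not confined to the ring carbon changed in compound 2, and that it also appears with an entering aromatic ring that carries no fluorine. Both listed replacements of a methyl by a six-membered aromatic ring lower the number, and neither goes against that pattern, though nothing available explains why the number falls at this position.

The compounds shown leave open how an ethyl group, a cyclopropyl ring or an amine would read at this carbon, and so whether an aromatic ring is needed for the fall at all. They also leave open how a 4-fluorophenyl on this same carbon would read, a comparison that would separate the presence of the fluorine from the choice of ring carbon.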